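Furan in place of chlorophenyl on a weakly active oxazole scaffold

The source may report more compounds than this note shows. Statements on the series, on what has been measured and on what is new or still open speak of the compounds shown alone.

Compound 2 `COc1cc(-c2cccc3nc(-c4cccc(Cl)c4)oc23)cc(OC)c1OC` is the stronger of the two compounds that return a number in a functional assay on U-251 cells (Homo sapiens) for antiproliferative activity, read by MTT assay, with a stated time of 48 h (a lower number here means a stronger inhibitor, a higher number a weaker inhibitor), where compound 2 gives 18500 nM. Its nearest neighbour is compound 3 `COc1ccc(-c2cccc3nc(-c4ccc5cc[nH]c5c4)oc23)c(OC)c1OC`, which in this assay gives 9500 nM, a gap that lies within the scatter, so no order between the two can be claimed. Compound 1 `COc1cc(-c2cccc3nc(-c4ccc(Br)cc4)oc23)cc(OC)c1OC` gives > 25000 nM, which is a limit of the assay and not a number.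

Compound 4 `COc1cc(-c2cccc3nc(-c4ccco4)oc23)cc(OC)c1OC` differs from compound 2 at one place: furan-2-yl in place of 3-chlorophenyl on an aromatic carbon. Among the compounds with values here, the only measured step at the same place is an at least 1.3-fold lower number from compound 1 to compound 2 (0.13 log units; that floor lies within the scatter), and because that step rests on the limit of > 25000 nM in this assay, at which 1 of the 3 values shown sits, its true size is unknown beyond its floor. Exchanging one aryl group for another at this position has therefore shown no effect beyond the scatter, and a step of similar size, in either direction or none, is expected here.

Compound 4 is accordingly expected to give 20000 nM, within 8000 nM to 60000 nM, which is estimated as a 1.1-fold higher number from compound 2 to compound 4 (0.03 log units; within the scatter).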

Compound 4, half-maximal inhibitory concentration: 10600 nM
Compound 4: middle estimate off by 1.9-fold (0.28 log units), on the high side; low and high end bracket the measured number.
By their numbers in this assay, from the lowest: compounds 3, 4 and 2 (each within the scatter of the next). At a limit, above all of these: compound 1.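

Putting furan-2-yl in place of 3-chlorophenyl gives a 1.7-fold lower number from compound 2 to compound 4 (0.24 log units; within the scatter) in this assay, so a five-membered aromatic ring with 1 hetero atom can stand at this position and the number stays in the range of compound 2. Set against 4-bromophenyl, the same group gives an at least 2.3-fold lower number from compound 1 to compound 4 (0.37 log units; beyond the scatter), the first step at this position that clears the scatter. The size of that step is only a floor, since compound 1 stands at a limit and not at a number: the limit of > 25000 nM in this assay, at which 1 of the 4 values shown sits.

Every group shown at this position is an aromatic ring, so the compounds leave open what an amine, a carboxylic acid or a longer alkyl chain would do here. Going by these compounds, whether furan-2-yl truly differs from 3-chlorophenyl also stays open, for that step remains within the scatter.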